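Bromo for nitro on the catechol ester series

This account rests on a few compounds, and the source may have more. Where it says the series, first, only, none or still open, it means among the compounds named here.

Compound 1 `O=C(/C=C/c1cc(O)c(O)c([N+](=O)[O-])c1)OCCc1ccccc1` in a functional assay on HepG2 cells (Homo sapiens) for inhibition, read by MTT assay (a higher number here means a weaker inhibitor, a lower number a stronger inhibitor), gives "not determined" (no result reported); compound 2 `O=C(/C=C/c1ccc(O)c(O)c1[N+](=O)[O-])OCCc1ccccc1` in this assay gives "not determined" (no result reported), so neither gives a number to work from. Among the compounds with values here, the only measured member is compound 3 `CC1(C)C2CCC1(C)C(OC(=O)/C=C/c1ccc(O)c(O)c1)C2`, which in this assay gives 31400 nM. Compound 4 `O=C(/C=C/c1cc(O)c(O)c(Br)c1)OCCc1ccccc1` differs from compound 1 by bromo in place of nitro on an aromatic carbon. With compound 1 lacking a value, no step can be read, and no direction beyond the scatter is claimed for the change from compound 1 to compound 4 in this assay. Resting on the weak result of compound 3 in this assay at 31400 nM, compound 4 is expected to fall near 20000 nM, between 5000 nM and 80000 nM.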

Compound 4, half-maximal inhibitory concentration: 4440 nM
Beside the measured number, compound 4's estimate is 4.5-fold (0.65 log units) above it, and the stated range ends above it.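

In this assay, within the data shown here, compound 1 gives "not determined" (no result reported) so no step from compound 1 to compound 4 can be read. The compounds shown leave open how bromo compares with nitro on the shared core. No evidence bearing on this result is available.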